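Swapping one sulfur-bearing side group on a shared core

The source may hold more compounds than are shown below. What is called first, only, known or untested is meant among the compounds shown, and "the series" means these compounds.

Measured in an ADME assay on CHO cells (Cricetulus griseus) for cytotoxicity, read by MTT assay; a lower number here means a stronger inhibitor, a higher number a weaker inhibitor:
- compound 1 `CS(=O)(=O)c1cccc(Nc2ccc3nccc(-c4ccncc4)c3n2)c1`: > 50000 nM (a limit)
- compound 2 `O=S(=O)(NCCN1CCCC1)c1cccc(-c2ccc3nccc(-c4ccnc(C(F)(F)F)c4)c3n2)c1`: 13000 nM
- compound 3 `O=S(=O)(CCO)c1cccc(-c2ccc3nccc(-c4ccncc4)c3n2)c1`: 26000 nM

Compound 1 reports only a limit, > 50000 nM, and not a number. Compound 3 gives 26000 nM and compound 2 gives 13000 nM, so these two lie within the usual scatter of each other and cannot be ranked.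

Compound 4 `CS(=O)(=O)Nc1cccc(-c2ccc3nccc(-c4ccncc4)c3n2)c1` keeps the core of compound 3 and changes one group: methanesulfonamido in place of (2-hydroxyethyl)sulfonyl on an aromatic carbon. Among the measured compounds shown here, no two measured compounds differ in only one place, so the data give no direct size for such a change. Compound 3 at 26000 nM is therefore the starting point, and no change beyond the scatter is expected in this assay. The expected step is a 1.1-fold higher number from compound 3 to compound 4 (0.03 log units; within the scatter). Compound 4 may also report only a limit. The estimated value for compound 4 is 28000 nM, with an expected range of 11000 nM to 60000 nM.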

Compound 4, half-maximal inhibitory concentration: 13000 nM
Compound 4: the middle estimate sits 2.2-fold (0.33 log units) above what was measured; the range from low to high includes it.
By their numbers in this assay, from the lowest: compounds 2, 4 and 3 (each within the scatter of the next). At a limit, above all of these: compound 1.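

In this assay, putting methanesulfonamido in place of (2-hydroxyethyl)sulfonyl gives a 2.0-fold lower number from compound 3 to compound 4 (0.30 log units; within the scatter), so the two groups cannot be told apart at this position, on an aromatic carbon meta to a large group. Among the compounds shown here, this is the first pair in the set that differs in only one place, which makes it the first direct reading of a single change on the shared core. Compound 3 and compound 4 both give numbers, whereas compound 1 reports only a limit: the limit of > 50000 nM in this assay, at which 1 of the 4 values shown sits.

The compounds shown leave open whether a carboxylic acid, an amine or a longer chain at this position would move the number beyond the scatter. They also leave open whether the same swap would give a similar step on the core of compound 2, which carries a trifluoromethyl group.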